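Two measured compounds and an open methoxy question

This account rests on a few compounds, and the source may have more. Where it says the series, first, only, none or still open, it means among the compounds named here.

Measured so far:
- compound 1 `CC(NC(=O)N1C(=O)c2ccccc2S1(=O)=O)c1ccccc1` with 0.663 h as its value
- compound 2 `O=C(NCc1cccc(Br)c1)N1C(=O)c2ccccc2S1(=O)=O` with 0.492 h as its value

Both numbers come from a physicochemical assay for pharmacokinetics (on this read-out higher numbers stand for a longer-lived compound and lower numbers for a shorter-lived compound), and they lie within the scatter of each other. Compound 2 therefore stands level with compound 1 on the present data, and nothing separates the two.

Within the data shown here, the next entry is compound 3 `COc1ccccc1CNC(=O)N1C(=O)c2ccccc2S1(=O)=O`, which keeps the shared core and carries 2-methoxyphenyl in place of 3-bromophenyl on a saturated chain carbon bound to an amide-type nitrogen as its only change from compound 2.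

Among the measured compounds shown here, no measured pair differs in one place only, so no single-change step is available as a guide. For the measured compounds named here, the only evidence is that compound 1 at 0.663 h and compound 2 at 0.492 h fall within the scatter of each other. On that basis, no shift beyond the scatter is expected in this assay, and neither direction is favoured. The expected change is a 1.1-fold higher number from compound 2 to compound 3 (0.05 log units; within the scatter) by estimate, which stays within the scatter.

Compound 3 is estimated at 0.55 h in this assay, with 0.3 h to 1 h as the expected range.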

Compound 3, half-life: 1.12 h
Estimate against measurement, compound 3: 2.0-fold (0.31 log units) below; the measured number lies above the stated range.
By their numbers in this assay, from the lowest: compounds 2, 1 and 3 (each within the scatter of the next, the first and the last beyond it).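

In this assay, among these compounds, 2-methoxyphenyl in place of 3-bromophenyl on a saturated chain carbon bound to an amide-type nitrogen gives a 2.3-fold higher number from compound 2 to compound 3 (0.36 log units; beyond the scatter), so this position can move the read-out beyond the scatter, which the earlier compounds could not show as they offered no single-change step. The step is a composite: the bromine leaves, a methoxy group with one hydrogen-bond acceptor enters, and the substituent's number in the group name changes from 3 to 2, so this one pair cannot assign the rise to any of these alone. No measurement shown here accounts for the rise.

Among the compounds shown here, still open is whether the rise follows the substituent or its place on the ring, a question that 2-bromophenyl and 3-methoxyphenyl at this position would separate, while compound 1 has no single-change step to either of the other two compounds and does not help. Also open, from the compounds shown here alone, is whether the higher number at this position would persist with a more different group on the ring, such as a carboxylic acid or an amine.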